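This account rests on a few compounds, and the source may have more. Where it says the series, first, only, none or still open, it means among the compounds named here.

Measured so far in a functional assay on HepG2 cells (Homo sapiens) for antiproliferative activity, read by MTT assay, with a stated time of 72 h; a higher number here means a weaker inhibitor, a lower number a stronger inhibitor:

compound 1, `COc1cc(CCc2ccc(F)cc2)cc(OC)c1O`: compound 1 gives 5470 nM
compound 2, `COc1cc(CCc2ccccc2F)cc(OC)c1O`: compound 2 gives 1030 nM

Compound 2 holds the lowest number of the two in this assay; its nearest neighbour is compound 1, whose number is higher by a gap beyond the usual scatter. For the measured compounds named here, the two compounds differ only in where the fluoro sits on the pendant ring, and no step between them has been worked out, so only the two values themselves are taken from this pair.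

Compound 3, `COc1ccccc1CCc1cc(OC)c(O)c(OC)c1`, has not yet been measured. It differs from compound 2 as follows: methoxy in place of fluoro on an aromatic carbon. Going by the values given here, no measured step covers such a swap, so the expectation rests on compound 2 alone. A small move toward a higher number is expected, a 1.9-fold higher number from compound 2 to compound 3 (0.29 log units; within the scatter), likely within or just beyond the scatter. Compound 3 is therefore estimated at 2000 nM in this assay, with a range of 700 nM to 6000 nM.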

Compound 3, half-maximal inhibitory concentration: 2480 nM
Beside the measured number, compound 3's estimate is 1.2-fold (0.09 log units) below it; the measured number falls inside the stated range.
By their numbers in this assay, from the lowest: compound 2; then compound 3; then compound 1.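

In this assay, this position, ortho to a large group, now has its first measured swap between two different groups: methoxy in place of fluoro gives a 2.4-fold higher number from compound 2 to compound 3 (0.38 log units; beyond the scatter). The earlier pair showed only that the placing of fluoro matters; this step shows that the group itself can also shift the number at this position. The step is modest, and methoxy, with its hydrogen-bond acceptor and larger heavy-atom count, remains compatible with activity in the low range seen so far. No accompanying measurement bears on why the number moves with this swap.

Still open, as far as these compounds go, is whether a small chloro or an amine at this position would match fluoro or fall nearer methoxy. A single step also leaves open whether size or acceptor count tracks with the number here.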